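The source may report more compounds than this note shows. Statements on the series, on what has been measured and on what is new or still open speak of the compounds shown alone.

Compound 1 `CCc1ccc(S(=O)(=O)NC(=O)Nc2ccc(Cl)cc2)s1`: 89%
Compound 2 `CC(C)c1ccc(S(=O)(=O)NC(=O)Nc2ccc(Cl)cc2)s1`: 63%
Compound 3 `CC(C)(C)c1ccc(S(=O)(=O)NC(=O)Nc2ccc(Cl)cc2)s1`: 10%

All three were tested in a functional assay on the whole organism (6C3HED cells, Mus musculus) for inhibition, at a dose of 300 mg/kg by the oral route; on this read-out higher numbers stand for more inhibition at the one dose given (going by the name of the read-out) and lower numbers for less inhibition. Compound 1 stands highest of the three; compound 2 is a number 26 percentage points lower from compound 1 to compound 2 (beyond the scatter), and compound 3 is a number 79 percentage points lower from compound 1 to compound 3 (beyond the scatter). Between the other two, compound 3 is a number 53 percentage points lower from compound 2 to compound 3 (beyond the scatter). So within this small set, each added methyl on the chain carbon bound to the ring lowered the read-out, first modestly and then sharply.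

Compound 4 `CCc1csc(S(=O)(=O)NC(=O)Nc2ccc(Cl)cc2)c1` has not yet been measured. It differs from compound 1 by a group of 7 heavy atoms (6 carbon, 1 sulfur; one five-membered aromatic ring with 1 hetero atom) in place of a group of 7 heavy atoms (6 carbon, 1 sulfur; one five-membered aromatic ring with 1 hetero atom), on a sulfonyl sulfur. Among the compounds with values here, no measured step bears directly on this change: the three steps above all concern growing the chain on the ring, while here the chain stays ethyl and the same atoms are simply joined differently. Those steps show only that this assay is sensitive to changes on this ring, so some loss is plausible but its size is uncertain. The step is expected to be a number 19 percentage points lower from compound 1 to compound 4 (beyond the scatter). Compound 4 is therefore expected to give about 70%, somewhere between 35% and 92%.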

Compound 4, a percentage reported as inhibition, in the whole organism at one dose (the size of the read-out at that dose, not a potency): 93%
The estimate for compound 4 lay 23 percentage points below the measured number; the whole stated range lies below it.
By their numbers in this assay, from the lowest: compound 3; then compound 2; then compounds 1 and 4 (each within the scatter of the next).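

In this assay, swapping the 5-ethylthiophen-2-yl group on the sulfonyl sulfur for its isomer, with the same atoms joined differently, gives a number 4 percentage points higher from compound 1 to compound 4 (within the scatter). Branching the chain cost a clear part of the read-out, but this rearrangement of the ring and its ethyl group leaves no difference that can be told from the scatter, so the group on the sulfonyl sulfur need not keep the joining seen in compound 1. Nothing available explains this outcome.

On these data alone, it remains open whether branching the chain would cost as much with the atoms joined as in compound 4, and how a propyl or butyl chain would fare there. A carboxylic acid in place of the ethyl group is also untested among these compounds, and a read-out at one dose cannot show whether compound 1 and compound 4 would match at other doses.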